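A few compounds are considered here, and "the series" means these few. Any claim that something is new, unique, unknown or untested is made for them only; others in the source may bear on it.

Three thiosemicarbazones built on a shared core, together with a fourth not yet measured, are compared in a functional assay on NCI-H460 cells (Homo sapiens) for inhibition, read by sulforhodamine B assay, with a stated time of 48 h; on this read-out higher numbers stand for weaker inhibition of growth and lower numbers for stronger inhibition of growth. Compound 1 `CC1=CC[C@H](C(C)(C)NC(=S)N/N=C/c2ccc(O)cc2)CC1` carries a 4-hydroxyphenyl group on the carbon with a double bond to nitrogen; in this assay compound 1 reaches only the limit > 100000 nM. Compound 2 `CC1=CC[C@H](C(C)(C)NC(=S)N/N=C/c2ccc(N(C)C)cc2)CC1` has dimethylamino in place of hydroxy on an aromatic carbon, and compound 2 likewise sits at the limit > 100000 nM. The step that the two limits leave unreadable from compound 1 to compound 2 therefore cannot be sized. For the measured compounds named here, compound 3 `CC1=CC[C@H](C(C)(C)NC(=S)N/N=C/c2cccc(Cl)c2)CC1` bears 3-chlorophenyl in place of 4-hydroxyphenyl, and compound 3 gives 21400 nM, the only number among the three values. The change from compound 1 to compound 3 is an at least 4.6-fold lower number from compound 1 to compound 3 (0.66 log units; beyond the scatter), a size that rests on (the limit of > 100000 nM in this assay, at which 2 of the 3 values shown sit). Compound 4 `CC1=CC[C@H](C(C)(C)NC(=S)N/N=C/c2ccc(Cl)cc2)CC1` differs from compound 3 only in that (4-chlorophenyl in place of 3-chlorophenyl on a carbon with a double bond to nitrogen). Going by the values given here, no measured step moves chlorine from one ring carbon to another, so the estimate for compound 4 is 25000 nM, expected to fall between 8000 nM and 80000 nM. The expected step of a 1.2-fold higher number from compound 3 to compound 4 (0.07 log units; within the scatter) is thus estimated to lie within the scatter.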

Compound 4, concentration for total growth inhibition: 21100 nM
For compound 4 the middle estimate is 1.2-fold (0.07 log units) above the measured one, and the stated range covers the measured number.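

Moving the chlorine from 3-chlorophenyl to 4-chlorophenyl makes no readable difference in this assay: the step is a 1.0-fold lower number from compound 3 to compound 4 (0.01 log units; within the scatter), so on a carbon with a double bond to nitrogen these two groups cannot be told apart. The gain seen earlier with chlorine therefore does not depend on one of these two placements, since chloro in place of dimethylamino gives an at least 4.7-fold lower number from compound 2 to compound 4 (0.67 log units; beyond the scatter) and chloro in place of hydroxy gives an at least 4.7-fold lower number from compound 1 to compound 4 (0.67 log units; beyond the scatter). Both of these sizes are minimum sizes, not exact ones, and they rest on a limit rather than a number: the limit of > 100000 nM in this assay, at which 2 of the 4 values shown sit.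

Going by these compounds, whether bromo or trifluoromethyl in the place of chloro would read the same remains open. So does whether 3-hydroxyphenyl would match 4-hydroxyphenyl, which would show if the indifference to placement extends beyond chlorine.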